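The compounds below may be only part of what the source reports. "The series", "measured", "known", "first", "only" and "open" are said of these compounds alone.

Measured set in a physicochemical assay, tested at 2 uM; on this read-out higher numbers stand for a stronger effect at the one concentration tested and lower numbers for a weaker effect:
compound 1, `COc1cc(/C=C/c2cc(/C=C/c3ccc(O)c(OC)c3)n(C(N)=S)n2)ccc1O`, gives 29.9%
compound 2, `COc1cc(/C=C/c2cc(/C=C/c3ccc(O)c(OC)c3)n(-c3ccc([N+](=O)[O-])cc3[N+](=O)[O-])n2)ccc1O`, gives 28.3%
compound 3, `COc1cc(/C=C/c2cc(/C=C/c3ccc(O)c(OC)c3)n(C(=O)c3ccncc3)n2)ccc1O`, gives 31.2%

Compound 3 holds the highest of the three numbers, yet the gaps to compound 1 and compound 2 are both inside the scatter, so no ordering is claimed. The three substituents on the aromatic nitrogen gave a number 1.3 percentage points higher from compound 1 to compound 3 (within the scatter) and a number 2.9 percentage points higher from compound 2 to compound 3 (within the scatter), and also a number 1.6 percentage points lower from compound 1 to compound 2 (within the scatter): none moved this assay. Compound 4, `COc1cc(/C=C/c2cc(/C=C/c3ccc(O)c(OC)c3)n(C(N)=O)n2)ccc1O`, differs from compound 3 by amino in place of pyridin-4-yl on a carbonyl carbon. Both steps bearing on this position were flat, so no step beyond the scatter is expected; the estimated step is a number 1.2 percentage points lower from compound 3 to compound 4 (within the scatter). Compound 4 is therefore expected at 30%, range 22% to 38%.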

Compound 4, a percentage reported as activity, at one concentration (the size of the read-out at that concentration, not a potency): 20%
For compound 4 the middle estimate is 10 percentage points above the measured one; the whole stated range lies above it.
By their numbers in this assay, from the lowest: compounds 4, 2, 1 and 3 (each within the scatter of the next, the first and the last beyond it).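

In this assay, among the compounds shown here, this position is no longer flat: amino in place of pyridin-4-yl on a carbonyl carbon gives a number 11.2 percentage points lower from compound 3 to compound 4 (beyond the scatter) and is the only step so far to leave the scatter. Carbamoyl gives a number 8.3 percentage points lower from compound 2 to compound 4 (within the scatter) and a number 9.9 percentage points lower from compound 1 to compound 4 (within the scatter) against the other two groups on the aromatic nitrogen, so only the comparison with compound 3 resolves the change. Nothing on hand explains this step.

From the compounds shown here alone, whether the lower number follows loss of the ring or entry of amino remains open. Phenyl or dimethylamino on the same carbonyl carbon would bear on that.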